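Replacing 4-nitrophenyl with 2,3,4-trimethoxyphenyl in a cytotoxicity test

A few compounds are considered here, and "the series" means these few. Any claim that something is new, unique, unknown or untested is made for them only; others in the source may bear on it.

In a functional assay on MCF7 cells (Homo sapiens) for cytotoxicity, read by MTT assay, with a stated time of 72 h (on this read-out lower numbers stand for stronger inhibition and higher numbers for weaker inhibition), compound 1 `O=C(N/N=C/c1ccc([N+](=O)[O-])cc1)Nc1cc2c(Nc3ccc(F)c(Cl)c3)ncnc2cc1O[C@H]1CCOC1` is reported as "not active" (no number reported) with no number attached, while compound 2 `COc1cc2ncnc(Nc3ccc(F)c(Cl)c3)c2cc1NC(=O)N/N=C/c1ccc([N+](=O)[O-])cc1` gives 36800 nM in the same measurement. Compound 2 therefore holds the only figure available, and there is no second number to rank it against. Compound 3 `COc1cc2ncnc(Nc3ccc(F)c(Cl)c3)c2cc1NC(=O)N/N=C/c1ccc(OC)c(OC)c1OC` keeps the core of compound 2 and alters one group. The change is 2,3,4-trimethoxyphenyl in place of 4-nitrophenyl on a carbon with a double bond to nitrogen and it amounts to 2,3,4-trimethoxyphenyl in place of 4-nitrophenyl on a carbon with a double bond to nitrogen. Within the data shown here, no pair of measured compounds differs in just one place, so nothing measured yet gives the size of such a swap. The expectation in this assay is therefore no step beyond the usual scatter of repeated measurements, in neither direction, although a report without a number remains possible. This expectation corresponds to an estimated 1.2-fold lower number from compound 2 to compound 3 (0.09 log units; within the scatter) and nothing larger. For compound 3 the estimated half-maximal inhibitory concentration is 30000 nM with an expected range from 8000 nM to 90000 nM in this measurement.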

Compound 3, half-maximal inhibitory concentration: "not active" (no number reported)
Compound 3: no number reported; there is nothing to compare the estimate with.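

Among these compounds, compound 3 is reported in this assay as "not active" without a number, so no step from compound 2 to compound 3 can be read. In this assay the compounds shown leave open how large a swap of 4-nitrophenyl for 2,3,4-trimethoxyphenyl is. No evidence available here bears on this result.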